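The source may report more compounds than this note shows. Statements on the series, on what has been measured and on what is new or still open speak of the compounds shown alone.

Of the compounds shown here, three built on a shared core have been measured in an assay on isolated protein for displacement of a labelled ligand from Apoptosis regulator Bcl-2 (Homo sapiens), read by fluorescence polarization; a lower number here means a stronger inhibitor, a higher number a weaker inhibitor. Compound 1 `CC1(C)CCN(c2ccc(C(=O)NS(=O)(=O)c3ccc(NC(C)(C)CSc4ccccc4)c([N+](=O)[O-])c3)cc2)CC1` gives 67 nM. Compound 2 `COC1(Cc2cccc(Cl)c2)CCN(c2ccc(C(=O)NS(=O)(=O)c3ccc(N[C@H](CCN(C)C)CSc4ccccc4)c([N+](=O)[O-])c3)cc2)CC1` gives 1.8 nM, and compound 3 `COc1ccccc1CC1(OC)CCN(c2ccc(C(=O)NS(=O)(=O)c3ccc(N[C@H](CCN(C)C)CSc4ccccc4)c([N+](=O)[O-])c3)cc2)CC1` gives 1.6 nM. Among these three numbers compound 2 stands second highest: compound 1 shows the highest number, and compound 3 lies closest to compound 2, the two being within the scatter of each other.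

The unmeasured compound 4 `COC1(Cc2ccccc2-c2ccccc2)CCN(c2ccc(C(=O)NS(=O)(=O)c3ccc(N[C@H](CCN(C)C)CSc4ccccc4)c([N+](=O)[O-])c3)cc2)CC1` differs from compound 2 in one place: 2-phenylphenyl in place of 3-chlorophenyl on a saturated chain carbon bound to a saturated ring carbon. Going by the values given here, the only measured step that bears on this change is the one from compound 2 to compound 3, where another aryl group replaced the 3-chlorophenyl at the same saturated chain carbon bound to a saturated ring carbon; that step was a 1.1-fold lower number from compound 2 to compound 3 (0.05 log units; within the scatter). On that single precedent, an exchange of the aryl group at this position has left the number essentially unchanged, and the larger 2-phenylphenyl is therefore expected to produce no step beyond the scatter in this assay. The step from compound 2 to compound 4 is expected to be no change at the digits printed from compound 2 to compound 4 (within the scatter). For compound 4 the estimated value in this assay is 1.8 nM, with a range from 0.7 nM to 5 nM.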

Compound 4, inhibition constant: < 1 nM
Compound 4: only a limit was reported; the forecaster's own chance of this, stated with the estimate: 5%; middle value at least 1.8-fold (0.25 log units) away from the limit.
By their numbers in this assay, from the lowest: compounds 3 and 2 (each within the scatter of the next); then compound 1. At a limit, below all of these: compound 4.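

In this assay compound 4 is reported only as a limit, < 1 nM. The earlier compounds shown here had exchanged one single-ring aryl group for another at this saturated chain carbon bound to a saturated ring carbon, whereas 2-phenylphenyl brings 12 heavy atoms and 2 six-membered aromatic rings in place of the 7 heavy atoms and one ring of 3-chlorophenyl, and the number still does not rise. The result reads as an at least 1.8-fold lower number from compound 2 to compound 4 (0.25 log units; that floor lies within the scatter) and as an at least 1.6-fold lower number from compound 3 to compound 4 (0.20 log units; that floor lies within the scatter), the latter being phenyl in place of methoxy on an aromatic carbon, and since both floors lie within the scatter, the second aromatic ring is shown to be accepted at this position, not to give a gain, with the reading stopping at the end of the assay's range: the limit of < 1 nM in this assay, at which 1 of the 4 values shown sits.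

On these data alone, how far compound 4 truly lies from compound 2 and compound 3 therefore stays open. Also open, as far as these compounds go, is whether the second ring needs to be aromatic, and how a cyclohexyl in its place, or an amine or a carboxylic acid carried on it, would read in this assay.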